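Phenyl for Trifluoromethyl in a Cytotoxicity Series

The source may hold more compounds than are shown below. What is called first, only, known or untested is meant among the compounds shown, and "the series" means these compounds.

Within the data shown here, in an ADME assay on MDBK cells (Bos taurus) for cytotoxicity (a lower number here means that less compound is tolerated, a higher number that more compound is tolerated), compound 3 `FC(F)(F)c1ccc(Cn2ccc3nc(-c4ccccc4)nc-3c2)cc1` gives 84000 nM, the only true number in this small set. Compound 1 `c1ccc(Cn2ccc3nc(-c4ccccc4)nc-3c2)cc1` reads > 100000 nM, which is a limit of the assay and not a number. Compound 2 `Fc1ccc(Cn2ccc3nc(-c4ccccc4)nc-3c2)cc1` reads > 100000 nM, which is also a limit. Among the measured compounds shown here, the series so far therefore rests largely on (the limit of > 100000 nM in this assay, at which 2 of the 3 values shown sit).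

Compound 4 `c1ccc(-c2ccc(Cn3ccc4nc(-c5ccccc5)nc-4c3)cc2)cc1` has phenyl in place of trifluoromethyl on an aromatic carbon, para to a large group (phenyl in place of trifluoromethyl on an aromatic carbon). Two measured changes at this place bear on it: an at least 1.1-fold lower number from compound 1 to compound 3 (0.07 log units; that floor lies within the scatter), and an at least 1.1-fold lower number from compound 2 to compound 3 (0.07 log units; that floor lies within the scatter). Both are only minimum sizes, and both lie within the scatter. No phenyl has yet been measured at this place, so the evidence is thin, but no clear shift is expected in this assay. The expected change is a 1.2-fold lower number from compound 3 to compound 4 (0.08 log units; within the scatter), which is estimated to stay within the scatter. The estimated value for compound 4 is 70000 nM, with an expected range from 25000 nM to 100000 nM.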

Compound 4, half-maximal cytotoxic concentration: 18000 nM
Beside the measured number, compound 4's estimate is 3.9-fold (0.59 log units) above it; measured number below the stated range.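

Among these compounds, at this position, on an aromatic carbon para to a large group, the change of group can clearly move the number in this assay: phenyl in place of trifluoromethyl gives a 4.7-fold lower number from compound 3 to compound 4 (0.67 log units; beyond the scatter), the first step here that is readable as lying beyond the scatter. Phenyl in place of fluoro gives an at least 5.5-fold lower number from compound 2 to compound 4 (0.74 log units; beyond the scatter), and phenyl in place of hydrogen gives an at least 5.5-fold lower number from compound 1 to compound 4 (0.74 log units; beyond the scatter), so compound 4 is tolerated at a lower concentration than each of the three earlier compounds. These last two steps are only minimum sizes, and their true size stays hidden: the limit of > 100000 nM in this assay, at which 2 of the 4 values shown sit.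

The compounds shown leave open whether a saturated ring such as cyclohexyl, an amine or a carboxylic acid at this place would lower the number as phenyl does. They also leave open whether the step seen with phenyl would carry over to another core.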